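The source may report more compounds than this note shows. Statements on the series, on what has been measured and on what is new or still open speak of the compounds shown alone.

Of the compounds shown here, three have been tested in a functional assay on DU-145 cells (Homo sapiens) for inhibition, read by trypan blue exclusion, with a stated time of 96 h; a higher number here means a weaker inhibitor of growth, a lower number a stronger inhibitor of growth. Compound 1 `CN(C)c1ccc(/C=C(\C(=O)c2ccc(Cl)cc2)S(=O)(=O)c2ccc(Br)cc2)cc1` carries a bromo group on one aromatic ring; in this assay compound 1 gives > 100000 nM, which is a limit of the assay rather than a number. Compound 2 `Cc1ccc(S(=O)(=O)/C(=C/c2ccc(N(C)C)cc2)C(=O)c2ccc(Cl)cc2)cc1` has a methyl in place of that bromo; in this assay compound 2 gives > 100000 nM, again a limit. The step that the two limits leave unreadable from compound 1 to compound 2 therefore cannot be read, because of the limit of > 100000 nM in this assay, at which 2 of the 3 values shown sit. Compound 3 `O=C(/C(=C\c1ccc(Oc2ccccc2)cc1)Sc1ccc(Br)cc1)c1ccc(Br)cc1` rests on a different core, and the difference between the two cores is not broken down here. In this assay compound 3 gives 50000 nM.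

Compound 4 `Cc1ccc(S/C(=C/c2ccc(Oc3ccccc3)cc2)C(=O)c2ccc(Br)cc2)cc1` has not yet been measured. It differs from compound 3 by methyl in place of bromo on an aromatic carbon. The same change separates compound 2 from compound 1, namely (methyl in place of bromo on an aromatic carbon), although the wider reading differs: sulfanyl in one pair, sulfonyl in the other. Since the measured pair gives no readable step, compound 4 is estimated at 60000 nM, within 20000 nM to 150000 nM, which corresponds to an expected step of a 1.2-fold higher number from compound 3 to compound 4 (0.08 log units; within the scatter).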

Compound 4, concentration for 50% growth inhibition: 1000 nM
Beside the measured number, compound 4's estimate is 60-fold (1.78 log units) above it; measured number outside the range, below it.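

On the core of compound 3, methyl in place of bromo gives a 50-fold lower number from compound 3 to compound 4 (1.70 log units; beyond the scatter) in this assay, a large change from one small swap on the aromatic ring. Whether it carries over to the core of compound 1 and compound 2, where the sulfanyl link is replaced by a sulfonyl link, cannot be judged, because both of those compounds sit at a limit of the assay rather than at a number: the limit of > 100000 nM in this assay, at which 2 of the 4 values shown sit. The result therefore rests on a single pair: it shows that the change can matter greatly on one core, but it gives no general rule for other cores and does not explain why the number falls.

The compounds shown leave open how a methoxy group, an ethyl group or a carboxylic acid on the same ring would compare with the methyl of compound 4. No pair shown changes the sulfur link alone, so its own contribution also remains open.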